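The source may report more compounds than this note shows. Statements on the series, on what has been measured and on what is new or still open speak of the compounds shown alone.

Among the compounds with values here, in a functional assay on SMMC-7721 cells (Homo sapiens) for inhibition, read by CCK-8 assay, with a stated time of 72 h, tested at 2 uM (a higher number here means more inhibition of growth at the concentration tested, a lower number less inhibition of growth), only two compounds with this shared core have been measured so far. Compound 1 `COc1ccc(SCc2ccc(/C=C/C(=O)Nc3ccccc3N)cc2)cc1OC` gives 14.3% and compound 2 `Nc1ccccc1NC(=O)/C=C/c1ccc(CSc2cccc(F)c2)cc1` gives 8.56%. Within the data shown here, those two numbers lie within the scatter of each other, so compound 2 cannot be separated from compound 1, the only measured compound to compare it with. Compound 3 `Nc1ccccc1NC(=O)/C=C/c1ccc(CSc2ccc(F)cc2)cc1` differs from compound 2 in one group: 4-fluorophenyl in place of 3-fluorophenyl on a sulfur. Put simply, 4-fluorophenyl stands in place of 3-fluorophenyl on a sulfur. Among the measured compounds shown here, one measured step bears on this, as it changes a group on the same sulfur: a number 5.7 percentage points lower from compound 1 to compound 2 (within the scatter). That step stayed within the scatter, so no change beyond the scatter is expected in this assay. The estimated change is a number 1.4 percentage points higher from compound 2 to compound 3 (within the scatter). Compound 3 is expected to give 10%, with an estimated range of 3% to 20%.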

Compound 3, percent growth inhibition at one concentration: 18.3%
Compound 3: middle estimate off by 8.3 percentage points, on the low side, within the range that was stated.
By their numbers in this assay, from the lowest: compounds 2, 1 and 3 (each within the scatter of the next).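

In this assay, 4-fluorophenyl in place of 3-fluorophenyl on the sulfur gives a number 9.7 percentage points higher from compound 2 to compound 3 (within the scatter), and 4-fluorophenyl in place of 3,4-dimethoxyphenyl gives a number 4 percentage points higher from compound 1 to compound 3 (within the scatter). With these steps, all three groups on this sulfur lie within the scatter of one another, so shifting the fluorine within the ring, like the earlier exchange of the whole ring substituents, cannot be separated from no change at this one concentration. No supporting measurement bears on this result.

From the compounds shown here alone, whether any group on this sulfur can move the read-out beyond the scatter remains open, for example a 4-chlorophenyl, a phenyl carrying a carboxylic acid or an amine, or a longer chain on the sulfur. Also open, going by these compounds, is how compounds 1, 2 and 3 would separate at other concentrations.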